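This account rests on a few compounds, and the source may have more. Where it says the series, first, only, none or still open, it means among the compounds named here.

Measured so far in an assay on membranes from Sf9 cells for displacement of a labelled ligand from histamine H2 receptor (Homo sapiens), read by scintillation counting, with a stated time of 60 min; a lower number here means a stronger inhibitor, a higher number a weaker inhibitor:
- compound 1 `N/C(=N\C(=O)NC1CCCCC1)Nc1cccc(-c2csc(N)n2)c1` gives 4470 nM
- compound 2 `Cc1nc(N)sc1CCCN/C(N)=N/C(=O)NC(c1ccccc1)C(C)C` gives 35.5 nM

Compound 2 stands at the lowest of the two numbers; its nearest neighbour, compound 1, sits at a far higher number, and that gap lies well beyond the scatter of this assay. The two share no single-point relationship, so their values only show that the chain-linked core of compound 2 is the one to follow.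

Compound 3 `Cc1nc(N)sc1CCCN/C(N)=N/C(=O)NCc1ccccc1` is the next member: it differs from compound 2 by hydrogen in place of isopropyl on a saturated chain carbon bound to an amide-type nitrogen and an aromatic carbon. Nothing measured yet bears on the removal of such a group from the shared core, so the direction rests on general expectation only. A modest weakening is expected, probably within or a little beyond the scatter, rather than a large shift.

Compound 3 is expected to give 100 nM in this assay, within 30 nM to 400 nM, a step of a 2.8-fold higher number from compound 2 to compound 3 (0.45 log units; beyond the scatter).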

Compound 3, inhibition constant: 69.2 nM
Beside the measured number, compound 3's estimate is 1.4-fold (0.16 log units) above it, within the range that was stated.
By their numbers in this assay, from the lowest: compounds 2 and 3 (each within the scatter of the next); then compound 1.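

In this assay, for the compounds shown here, hydrogen in place of isopropyl on a saturated chain carbon bound to an amide-type nitrogen and an aromatic carbon gives a 1.9-fold higher number from compound 2 to compound 3 (0.29 log units; within the scatter), the first single-place reading. The isopropyl group, with its 3 heavy atoms, can therefore be removed from this carbon without a shift beyond the scatter, and compounds 2 and 3 cannot be ordered on these numbers. No measurement shown accounts for this result.

A single methyl, a longer chain, a hydroxyl or an amine on this carbon could still give a number beyond the scatter, since only hydrogen and isopropyl are shown there. As far as these compounds go, it also remains open whether the same replacement would behave alike on the core of compound 1.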